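The source may hold more compounds than are shown below. What is called first, only, known or untested is meant among the compounds shown, and "the series" means these compounds.

Compound 1 `O=C1NC(O)C(F)=CN1[C@H]1C=C[C@@H](CO)O1`: 4200 nM
Compound 2 `Nc1nc(=O)n([C@H]2C=C[C@@H](CO)O2)cc1Br`: > 100000 nM

Both compounds were tested in a functional assay on SK-MES-1 cells (Homo sapiens) for antiproliferative activity; on this read-out higher numbers stand for weaker inhibition and lower numbers for stronger inhibition. Compound 1 gives a measured number. Compound 2 gives > 100000 nM, which is a limit of the assay and not a number. That places compound 2 at the limit of > 100000 nM in this assay, at which 1 of the 2 values shown sits.

Compound 3 `Nc1nc(=O)n([C@H]2C=C[C@@H](CO)O2)cc1I` has not yet been measured. It departs from compound 2 in one place: iodo in place of bromo on an aromatic carbon. This is iodo in place of bromo on an aromatic carbon, ortho to an amino group. Among the compounds with values here, no measured pair shows what this swap does in this assay, so the expectation is a cautious one. The expected step is a number no higher from compound 2 to compound 3 (the limit leaves the size open), which means no shift beyond the usual scatter in either direction. For compound 3 the estimated value is 100000 nM, with an expected range from 20000 nM to 200000 nM.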

Compound 3, half-maximal inhibitory concentration: > 100000 nM
Compound 3 was reported as a limit; the forecaster's own chance of this, stated with the estimate: 65%; the middle value sits exactly at the limit.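

Compound 2 and compound 3 both stand at a limit and not at a number, so no step can be read between them: the limit of > 100000 nM in this assay, at which 2 of the 3 values shown sit. The compounds shown leave open whether iodo in place of bromo changes antiproliferative activity at all, and by how much.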